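A few compounds are considered here, and "the series" means these few. Any claim that something is new, unique, unknown or untested is made for them only; others in the source may bear on it.

Going by the values given here, in a functional assay on MDA-MB-435 cells (Homo sapiens) for antiproliferative activity, read by sulforhodamine B assay, with a stated time of 48 h (a higher number here means a weaker inhibitor, a lower number a stronger inhibitor), compound 1 `COc1ccc(-c2nsc3c2NC(=O)CC3c2cccc(F)c2)cc1` gives 827 nM and compound 2 `COc1ccc(-c2nsc3c2NC(=O)CC3c2ccsc2)cc1` gives 23.5 nM, the lower of the two numbers so far. Compound 3 `O=C1CC(c2ccsc2)c2snc(-c3ccc(Cl)cc3)c2N1` is still unmeasured. It differs from compound 2 as follows: chloro in place of methoxy on an aromatic carbon, para to a large group.

Among the compounds with values here, the only measured step, a 35-fold lower number from compound 1 to compound 2 (1.55 log units; beyond the scatter), lies on a saturated ring carbon and not at this place, so it gives no direction for the new change. Within the data shown here, it shows only that a single change can move the number a long way. With compound 2 at 23.5 nM, a moderate step to a higher number is expected in this assay, though the data do not settle the direction. The estimated move is a 5.1-fold higher number from compound 2 to compound 3 (0.71 log units; beyond the scatter). Compound 3 is estimated at 120 nM, with an expected range of 30 nM to 500 nM.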

Compound 3, half-maximal inhibitory concentration: 260 nM
Estimate against measurement, compound 3: 2.2-fold (0.34 log units) below; the measured number falls inside the stated range.
By their numbers in this assay, from the lowest: compound 2; then compound 3; then compound 1.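

In this assay, the aromatic carbon para to a large group proves sensitive: chloro in place of methoxy gives an 11-fold higher number from compound 2 to compound 3 (1.04 log units; beyond the scatter). The saturated ring carbon is therefore not the only place in the series where one change moves the number beyond the scatter, and with this step methoxy is the better of the two groups tested here, with thiophen-3-yl held constant. Nothing available accounts for the size of this step.

The compounds shown leave open how a hydroxy, an ethoxy or an amine at this place would compare with methoxy and chloro. They also leave open whether chloro in place of methoxy would move the number as far with 3-fluorophenyl on the saturated ring carbon, as in compound 1.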